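Shortening the sulfur-bound chain from octyl to isopropyl

This account rests on a few compounds, and the source may have more. Where it says the series, first, only, none or still open, it means among the compounds named here.

The shared core of compound 1 `Nc1nc(NCc2ccccc2)c2ncn(/C=C3/CC3(CO)CO)c2n1` carries a benzylamino group on an aromatic carbon. In an ADME assay on CCRF-HSB-2 cells (Homo sapiens) for cytotoxicity, with a stated time of 7 days (on this read-out higher numbers stand for lower toxicity in this test and lower numbers for higher toxicity in this test), compound 1 gives > 20000 nM, which is a limit of the test rather than a number. Compound 2 `CCCCCCCCSc1nc(N)nc2c1ncn2/C=C1/CC1(CO)CO` has octylsulfanyl in place of benzylamino on that carbon, and in this assay compound 2 gives 60000 nM, the only true number shown. The step that the limit leaves unreadable from compound 1 to compound 2 cannot be read in size, since the limit of > 20000 nM in this assay, at which 1 of the 2 values shown sits, hides the starting point. Compound 3 `CC(C)Sc1nc(N)nc2c1ncn2/C=C1/CC1(CO)CO` differs from compound 2 by isopropyl in place of octyl on a sulfur. No measured step touches the length of the chain on the sulfur, so no direction can be drawn from the shown pairs, and a step within the usual scatter is expected. The estimate for compound 3 is therefore 60000 nM, between 20000 nM and 180000 nM, which means an expected step of no change at the digits printed from compound 2 to compound 3 (within the scatter).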

Compound 3, half-maximal cytotoxic concentration: 94000 nM
The estimate for compound 3 lay 1.6-fold (0.19 log units) below the measured number, and the stated range covers the measured number.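

Putting isopropyl in place of octyl on the sulfur gives a 1.6-fold higher number from compound 2 to compound 3 (0.19 log units; within the scatter) in this assay. Within the data shown here, this is the first step at this position that can be read in size, and it shows that, for these two chains, the much shorter one cannot be told apart from the longer one in this test. The step from compound 1 to compound 3 cannot be read, because the value of compound 1 is a limit and not a number: the limit of > 20000 nM in this assay, at which 1 of the 3 values shown sits.

Still open, from the compounds shown here alone, is whether this holds for other groups on the sulfur, such as a phenyl ring or a chain ending in a carboxylic acid. Also open, going by these compounds, is how an amine carrying an octyl or isopropyl chain would compare with these sulfur-linked groups on the same aromatic carbon.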